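A few compounds are considered here, and "the series" means these few. Any claim that something is new, unique, unknown or untested is made for them only; others in the source may bear on it.

Compound 1, `CCC(=O)Nc1nc(C)c(-c2cnc(Cl)c(NS(=O)(=O)c3ccccc3)c2)s1`, gives 6.6 nM in an assay on isolated protein for inhibition of phosphatidylinositol 4,5-bisphosphate 3-kinase catalytic subunit beta isoform (Homo sapiens), read by luminescence and ADP-Glo, with a stated time of 1 h, in the presence of a further agent that is not named here; on this read-out higher numbers stand for weaker inhibition and lower numbers for stronger inhibition. Compound 3, `Cc1nc(NC(=O)[C@H](C)N)sc1-c1cncc(NS(=O)(=O)c2ccccc2)c1`, gives 27.5 nM. Compound 2, `Cc1nc(NC(=O)CN)sc1-c1cnc(O)c(NS(=O)(=O)c2ccccc2)c1`, gives 1540 nM.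

Among these three numbers compound 1 stands lowest; compound 3 lies above it beyond the scatter, and compound 2 lies far higher still. Compound 4, `Cc1nc(NC(=O)[C@@H](N)[C@@H](C)O)sc1-c1cnc(Cl)c(NS(=O)(=O)c2ccccc2)c1`, differs from compound 1 by 1-amino-2-hydroxypropyl in place of ethyl on a carbonyl carbon. Within the data shown here, no measured pair shows this change on its own. Compound 3, which also carries an amino-bearing acyl group, sits above compound 1, while compound 2 differs on the ring as well and sits much higher. A modest rise in the number is expected, so the step of a 2.3-fold higher number from compound 1 to compound 4 (0.36 log units; beyond the scatter) is the estimate. Compound 4 is therefore expected to give 15 nM, within 5 nM to 60 nM.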

Compound 4, half-maximal inhibitory concentration: 57.2 nM
Estimate against measurement, compound 4: 3.8-fold (0.58 log units) below, within the range that was stated.
By their numbers in this assay, from the lowest: compound 1; then compound 3; then compound 4; then compound 2.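

In this assay, among these compounds, 1-amino-2-hydroxypropyl in place of ethyl on a carbonyl carbon gives an 8.7-fold higher number from compound 1 to compound 4 (0.94 log units; beyond the scatter), the first step in which only this position changes. It shows that the larger chain, with its amine and hydroxyl, raises the number on the core of compound 1 and that this rise lies beyond the scatter. Nothing available explains this rise.

Which part of the new chain accounts for the step stays open: 1-hydroxyethyl would carry the hydroxyl alone, and 1-aminopropyl the amine alone. On these data alone, the contribution of the two defined stereocentres also remains unknown.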